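The compounds below may be only part of what the source reports. "The series", "measured", "known", "first", "only" and "open" are said of these compounds alone.

Measured so far:
- compound 1, `Cc1ccc2nc(Nc3ccnc(Nc4ccc(S(C)(=O)=O)cc4)n3)sc2c1`: 4440 nM
- compound 2, `Cc1cnc(Nc2ccc(S(N)(=O)=O)cc2)nc1Nc1nc2ccccc2s1`: 16800 nM

In a functional assay on MDA-MB-231 cells (Homo sapiens) for antiproliferative activity, read by MTT assay, with a stated time of 48 h (a higher number here means a weaker inhibitor, a lower number a stronger inhibitor), compound 1 gives 4440 nM, the lowest of the two numbers recorded. Compound 2 gives 16800 nM in this assay, a higher number, and the gap between the two lies beyond the scatter; the two compounds differ in more than one place, so nothing further can be read from that pair.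

Compound 3, `CS(=O)(=O)c1ccc(Nc2nccc(Nc3nc4ccc(Cl)cc4s3)n2)cc1`, is not yet measured. It is derived from compound 1 by chloro in place of methyl on an aromatic carbon. Among the measured compounds shown here, no measured pair shows a change of this kind, so the size of the step from compound 1 to compound 3 is unknown; a small step is expected, in either direction, and probably not beyond the scatter. On that basis compound 3 is estimated at 3500 nM in this assay, the expected step being a 1.3-fold lower number from compound 1 to compound 3 (0.10 log units; within the scatter), with a range from 1200 nM to 10000 nM.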

Compound 3, half-maximal inhibitory concentration: > 50000 nM
Compound 3: only a limit was reported (the forecaster's own chance of this, stated with the estimate: 3%); at least 14-fold (1.15 log units) between middle value and limit.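

In this assay, chloro in place of methyl on an aromatic carbon gives an at least 11-fold higher number from compound 1 to compound 3 (1.05 log units; beyond the scatter), so one heavy atom exchanged at this place, with no change in the counts of rings, donors, acceptors or charge, is enough to separate compound 3 from compound 1 by far more than the scatter. Among the compounds shown here, for compound 3 the value of > 50000 nM is a limit and not a number, so the step has a lower bound but no fixed size: the limit of > 50000 nM in this assay, at which 1 of the 3 values shown sits. This is the first pair with a single change, and it shows that this position is sensitive to substitution.

One pair cannot tell whether the shift follows from chloro entering or from methyl leaving, and a hydrogen, a fluoro, a methoxy or an amine at this place would be needed to separate the two. Compound 2 differs from compound 1 in more than one place and adds nothing on this position.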